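The source may report more compounds than this note shows. Statements on the series, on what has been measured and on what is new or still open speak of the compounds shown alone.

Measured so far in an ADME assay on BaF3 cells (Mus musculus) for antiproliferative activity, read by CellTiter-Glo and CCK-8 assay, with a stated time of 72 h; a higher number here means a weaker inhibitor of growth, a lower number a stronger inhibitor of growth:

- compound 1, `Cc1ccc(Nc2ncc3c(n2)N(C)C(=O)N(c2cc(NC(=O)c4cccc(C(F)(F)F)c4)ccc2C)C3)cc1`: 8000 nM
- compound 2, `Cc1ccc(Nc2ncc3c(n2)N(C)C(=O)N(c2cc(NC(=O)c4cccc(C(F)(F)F)c4)ccc2C)C3)cc1N(C)C`: > 10000 nM, which is a limit of the assay and not a number
- compound 3, `Cc1ccc(Nc2ncc(C(=O)Nc3cc(NC(=O)c4cccc(C(F)(F)F)c4)ccc3C)c(N(C)C)n2)cc1N`: > 10000 nM, again a limit and not a number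

Two of the three values sit at the limit of > 10000 nM in this assay, at which 2 of the 3 values shown sit, so only compound 1 gives a number. Among the compounds with values here, the one step that can be counted is an at least 1.2-fold lower number from compound 2 to compound 1 (0.09 log units; that floor lies within the scatter), made by hydrogen in place of dimethylamino on an aromatic carbon. The cores of compound 2 and compound 3 differ, but that difference is not broken down here.

Compound 4, `Cc1ccc(Nc2ncc(C(=O)Nc3cc(NC(=O)c4cccc(C(F)(F)F)c4)ccc3C)cn2)cc1N`, is not yet measured. It arises from compound 3 by hydrogen in place of dimethylamino on an aromatic carbon. This is the same kind of change as from compound 2 to compound 1, but it sits on a different ring: on a six-membered aromatic ring with 2 nitrogen, next to the ring nitrogen, ortho to a large group, rather than on a ring of carbon only, ortho to a methyl group. Because the earlier step, an at least 1.2-fold lower number from compound 2 to compound 1 (0.09 log units; that floor lies within the scatter), lies within the scatter, the expected step of a number no higher from compound 3 to compound 4 (the limit leaves the size open) is small. Compound 4 is estimated at 10000 nM, with a likely range from 4000 nM to 30000 nM.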

Compound 4, concentration for 50% growth inhibition: > 10000 nM
Compound 4 ended at the assay's limit (the forecaster's own chance of this, stated with the estimate: 50%); the middle value lies on the limit itself.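

In this assay compound 4 gives > 10000 nM as a limit of the assay and not a number. Within the data shown here, compound 3 also stands at a limit, so no step from compound 3 to compound 4 can be read: the limit of > 10000 nM in this assay, at which 3 of the 4 values shown sit. The compounds shown leave open whether hydrogen in place of dimethylamino changes growth inhibition on the core of compound 3 at all.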